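The source may hold more compounds than are shown below. What is called first, only, known or untested is meant among the compounds shown, and "the series" means these compounds.

In an ADME assay on a cell-free system (plasma, Rattus norvegicus) for metabolic stability, read by LC-MS, with a stated time of 60 min, tested at 100 uM (a lower number here means that less of the compound is left, a higher number that more of the compound is left), compound 1 `Cc1c(OCCCCOc2ccc(C(=O)O)cc2F)ccc(C(=O)CC2CCCC2)c1O` gives 97%. For the measured compounds named here, the only other measured compound, compound 2 `Cc1c(OCCCCOc2ccc(C(=O)O)cc2F)ccc(C(=O)CC(C)C)c1O`, gives 106%, so the two cannot be told apart and compound 1 holds no separate rank. Compound 3 `Cc1c(OCCCCOc2cccc(C(=O)O)c2)ccc(C(=O)CC2CCCC2)c1O` keeps the cyclopentyl group of compound 1 but differs elsewhere: 3-carboxyphenyl in place of 4-carboxy-2-fluorophenyl on an oxygen on a saturated carbon. In words, 3-carboxyphenyl stands in place of 4-carboxy-2-fluorophenyl on an oxygen on a saturated carbon. Going by the values given here, no measured step touches this place, since both measured compounds carry the 4-carboxy-2-fluorophenyl group. Among the compounds with values here, the one available step, a number 9 percentage points higher from compound 1 to compound 2 (within the scatter), is a different change, isopropyl in place of cyclopentyl on a saturated chain carbon bound to a carbonyl carbon. It bears on compound 3 only indirectly, showing that one structural change left the reading within the scatter. On that thin evidence, no step beyond the scatter is expected in this assay. The expected change is a number 1 percentage points higher from compound 1 to compound 3 (within the scatter), which would stay within the scatter. For compound 3 the estimated value is 98%, with an expected range from 85% to 110%.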

Compound 3, percent of the compound remaining: 99%
Beside the measured number, compound 3's estimate is 1 percentage points below it; low and high end bracket the measured number.
By their numbers in this assay, from the lowest: compounds 1, 3 and 2 (each within the scatter of the next).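

For the compounds shown here, with the cyclopentyl group held fixed, the change on an oxygen on a saturated carbon, from 4-carboxy-2-fluorophenyl to 3-carboxyphenyl, gives in this assay a number 2 percentage points higher from compound 1 to compound 3 (within the scatter), the first reading at this place. The two groups therefore cannot be told apart in this assay, and, together with a number 9 percentage points higher from compound 1 to compound 2 (within the scatter), this shows that single changes at two separate places of compound 1 both stayed within the scatter. Nothing available speaks to the reason for this result.

Every step shown stays within the scatter. The compounds do not reveal any change at either place that would separate one reading from another. Going by these compounds, it remains open whether the result would hold with a methyl ester or an amide in place of the carboxylic acid, or with a longer chain on that oxygen.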